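The compounds below may be only part of what the source reports. "The series", "measured", "known", "first", "only" and "open" are said of these compounds alone.

Measured in a functional assay on RPMI-8226 cells (Homo sapiens) for inhibition, read by sulforhodamine B assay, with a stated time of 48 h, tested at 10 uM; on this read-out lower numbers stand for less inhibition and higher numbers for more inhibition at the one concentration tested (going by the name of the read-out):
compound 1 `COc1ccc(-c2cn3ccnc3c(-c3ccc4ncn(C5CCCCC5)c4c3)n2)cc1` — 95.6%
compound 2 `Fc1ccc(-c2cn3ccnc3c(-c3ccc4ncn(C5CCCCC5)c4c3)n2)cc1` — 50.1%
compound 3 `COc1ccccc1-c1cn2ccnc2c(-c2ccc3ncn(C4CCCCC4)c3c2)n1` — 35.9%

Compound 4 `Fc1ccccc1-c1cn2ccnc2c(-c2ccc3ncn(C4CCCCC4)c3c2)n1` is not yet measured. Compound 3 stands lowest of the three, with compound 2 nearest, as a number 14.2 percentage points lower from compound 2 to compound 3 (beyond the scatter) shows, and compound 1 furthest, as a number 59.7 percentage points lower from compound 1 to compound 3 (beyond the scatter) shows. The cores of compound 1 and compound 3 differ as described by 2-methoxyphenyl in place of 4-methoxyphenyl on an aromatic carbon.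

The change from compound 3 to compound 4 is fluoro in place of methoxy on an aromatic carbon. The same kind of change is known once, from compound 1 to compound 2, as fluoro in place of methoxy on an aromatic carbon, where it gave a number 45.5 percentage points lower from compound 1 to compound 2 (beyond the scatter). The surroundings are not identical: in the known case the place is para to a large group, here it is ortho to a large group, so the earlier step is a guide rather than a copy.

Because compound 3 already gives 35.9%, a step as large as a number 45.5 percentage points lower from compound 1 to compound 2 (beyond the scatter) cannot repeat in full; the expected step is a number 15.9 percentage points lower from compound 3 to compound 4 (beyond the scatter), smaller than the earlier one. Compound 4 is estimated at 20%, expected between 2% and 45%.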

Compound 4, a percentage reported as inhibition, at one concentration (the size of the read-out at that concentration, not a potency): 42.4%
For compound 4 the middle estimate is 22.4 percentage points below the measured one, within the range that was stated.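

In this assay, fluoro in place of methoxy does not carry from one core to the other as a fixed step, and the two cases clearly part: the same change on two cores in this assay, a number 45.5 percentage points lower (beyond the scatter) from compound 1 to compound 2 and a number 6.5 percentage points higher (within the scatter) from compound 3 to compound 4, 52 percentage points apart, beyond the scatter of two such steps. With the group ortho to a large group, the change gives a number 6.5 percentage points higher from compound 3 to compound 4 (within the scatter), and the 2-fluorophenyl compound also shows a number 7.7 percentage points lower from compound 2 to compound 4 (within the scatter), while the distance to the 4-methoxyphenyl compound stays wide, with a number 53.2 percentage points lower from compound 1 to compound 4 (beyond the scatter). Two pairs show that the step depends on the surroundings of the change, but they do not show why, nor do they give a rule that would hold for any further core in the series.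

The compounds shown leave open how other groups at the same place on the phenyl ring would read, such as an amine or a carboxylic acid. With each compound read at one concentration, they also leave open how the compounds compare in potency.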